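This account rests on a few compounds, and the source may have more. Where it says the series, first, only, none or still open, it means among the compounds named here.

Compound 3 `COc1cc(C(=O)c2ccc3c(ccn3S(=O)(=O)c3cccc(/C=C/C(=O)NO)c3)c2)cc(OC)c1OC` gives 1260 nM in an assay on isolated protein for inhibition of histone deacetylase 8 (Homo sapiens) (a higher number here means a weaker inhibitor, a lower number a stronger inhibitor), the second highest of the three numbers measured. Compound 1 `COc1cc(C(=O)c2ccc3c(ccn3S(=O)(=O)c3ccc(/C=C/C(=O)NO)cc3)c2)cc(OC)c1OC` gives 5340 nM in this assay, and compound 2 `COc1ccc(C(=O)c2ccc3c(ccn3Cc3ccc(C(=O)NO)cc3)c2)cc1` gives 646 nM; the gap between compound 3 and compound 2 lies within the scatter. Within the data shown here, the only single-point step measured so far is a 4.2-fold lower number from compound 1 to compound 3 (0.63 log units; beyond the scatter), which leaves the trimethoxyphenyl ring untouched. Compound 4 `COc1ccc(C(=O)c2ccc3c(ccn3S(=O)(=O)c3cccc(/C=C/C(=O)NO)c3)c2)cc1OC` differs from compound 3 by hydrogen in place of methoxy on an aromatic carbon. Among the measured compounds shown here, no measured step bears on this change; compound 2 also differs at the methoxy groups, but it differs from compound 3 in more than one place, so its value is no direct guide. Compound 4 is therefore expected to show a 1.1-fold lower number from compound 3 to compound 4 (0.02 log units; within the scatter), no step beyond the scatter. The estimate for compound 4 in this assay is 1200 nM, with a range from 450 nM to 3200 nM.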

Compound 4, half-maximal inhibitory concentration: 1420 nM
Beside the measured number, compound 4's estimate is 1.2-fold (0.07 log units) below it; the range from low to high includes it.
By their numbers in this assay, from the lowest: compounds 2, 3 and 4 (each within the scatter of the next, the first and the last beyond it); then compound 1.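

In this assay, among these compounds, the first measured step on this ring, from 3,4,5-trimethoxyphenyl to 3,4-dimethoxyphenyl, reads a 1.1-fold higher number from compound 3 to compound 4 (0.05 log units; within the scatter) and stays within the scatter. With 3-(2-(hydroxycarbamoyl)ethenyl)phenyl held on the sulfonyl sulfur, this methoxy can therefore be replaced by hydrogen without a change beyond the scatter. Nothing available bears on the reason for this result.

Going by these compounds, what an amine or a longer alkoxy chain would give at this place remains open. Also open, on these data alone, is whether the same replacement would read alike with the 4-(2-(hydroxycarbamoyl)ethenyl)phenyl of compound 1.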